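The compounds below may be only part of what the source reports. "The series", "measured", "known", "first", "only" and "open" are said of these compounds alone.

Of the compounds shown here, two sharing one core have been tested in a functional assay on Umbilical vein for antagonist activity at B1 bradykinin receptor (Homo sapiens), using Schild analysis, with a stated time of 30 min; on this read-out higher numbers stand for higher potency (the scale is a negative logarithm) and lower numbers for lower potency. Compound 1 `COc1cc(C)c(S(=O)(=O)N(C)CCOCC(=O)N2CCC(C(C)(C)CN(C)C)CC2)c(C)c1` gives 7.5 there. Compound 2 `COc1cc(C)c(S(=O)(=O)N(C)CCOCC(=O)N2CCN([C@@H]3CN4CCC3CC4)CC2)c(C)c1` gives 8.1, the higher of the two numbers, and its gap to compound 1 lies beyond the usual scatter. Compound 3 `COc1cc(C)c(S(=O)(=O)N(C)CCOCC(=O)N2CCN(CCCN(C)C)CC2)c(C)c1` differs from compound 2 in a single place: a group of 6 heavy atoms (5 carbon, 1 nitrogen; no ring) in place of a group of 8 heavy atoms (7 carbon, 1 nitrogen; 2 six-membered non-aromatic rings with 1 hetero atom each), on an amine nitrogen in a ring. Among the measured compounds shown here, no measured pair shows this particular step. In this assay a downward step beyond the scatter is expected for compound 3, a number 0.70 log units lower from compound 2 to compound 3 (beyond the scatter). Compound 3 is therefore estimated at 7.4, with a range from 6.7 to 8.1.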

Compound 3, negative logarithm of the antagonist equilibrium constant: 7.9
Beside the measured number, compound 3's estimate is 0.50 log units below it; low and high end bracket the measured number.
By their numbers in this assay, from the lowest: compound 1; then compounds 3 and 2 (each within the scatter of the next).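

In this assay, with 3-(dimethylamino)propyl on the amine nitrogen in the ring in place of the group with 2 six-membered non-aromatic rings, the change gives a number 0.20 log units lower from compound 2 to compound 3 (within the scatter) and no more. Among the compounds shown here, this position therefore tolerates an open chain without a ring or a defined stereocentre, and the number stays within the scatter of the one for the ring-bearing group. Nothing available explains this result. The compounds shown leave open how a shorter or longer chain ending in dimethylamino would fare at this position. They also leave open whether a chain ending in a carboxylic acid would keep the number.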